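The compounds below may be only part of what the source reports. "The series", "measured", "known", "first", "only" and "open" are said of these compounds alone.

Measured in a functional assay on Vero cells (Chlorocebus sabaeus) for inhibition; a lower number here means a stronger inhibitor, a higher number a weaker inhibitor:
- compound 1 `OC[C@H]1O[C@H](n2cnc3c(O)ncnc32)CS1`: > 100000 nM
- compound 2 `O=c1[nH]c(=O)n([C@@H]2CS[C@@H](CO)O2)cc1Cl`: > 100000 nM

Both entries are limits of the assay, not numbers. Among the measured compounds shown here, the series so far reads as follows: the limit of > 100000 nM in this assay, at which 2 of the 2 values shown sit. In this assay compound 2 gives > 100000 nM, which is a limit, so it fixes no exact position for compound 2. For the measured compounds named here, no measured step connects any pair of compounds, so the effect of a single substitution cannot be read from the series.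

The next compound is compound 3 `Cc1cn([C@@H]2CS[C@@H](CO)O2)c(=O)[nH]c1=O`, which carries methyl in place of chloro on an aromatic carbon of compound 2: methyl in place of chloro on an aromatic carbon. No step beyond the usual scatter is expected in this assay, and neither direction is favoured. This expectation rests on compound 2, with its limit of > 100000 nM, and on the single replacement. The estimated step is a number no higher from compound 2 to compound 3 (the limit leaves the size open). A report of compound 3 as another limit is expected to be the likeliest outcome. For compound 3 the estimated value is 100000 nM, with an expected range of 30000 nM to 300000 nM.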

Compound 3, half-maximal inhibitory concentration: > 100000 nM
Compound 3 ended at the assay's limit (the forecaster's own chance of this, stated with the estimate: 75%); the middle value sits exactly at the limit.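

In this assay compound 3 gives > 100000 nM, a limit and not a number. Compound 2 also stands at a limit, so no step can be read between compound 2 and compound 3, where methyl replaces chloro. The compounds shown leave open what potency any of them has and what a single replacement changes: the limit of > 100000 nM in this assay, at which 3 of the 3 values shown sit.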